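The compounds below may be only part of what the source reports. "The series", "measured", "known", "first", "only" and "open" are said of these compounds alone.

Measured in a functional assay on MCF7 cells (Homo sapiens) for cytotoxicity, read by MTT assay; a higher number here means a weaker inhibitor, a lower number a stronger inhibitor:
- Compound 1 `COC(=O)C[C@@H]1C[C@@H](O)[C@H](C)[C@H](c2ccccc2)N1`: 5400 nM
- Compound 2 `COC(=O)C[C@H]1C[C@H](O)[C@@H](C)[C@@H](c2ccc(C)cc2)N1`: "not active" (no number reported)
- Compound 3 `COC(=O)C[C@H]1C[C@@H](O)[C@@H](C)[C@@H](c2ccc(C(C)C)cc2)N1`: "not active" (no number reported)

Among the compounds with values here, only one of the three compounds has a number in this assay. Compound 1, at 5400 nM, is therefore the sole numerical reference point. Compound 2 is recorded as "not active" (no number reported), and compound 3 is likewise recorded as "not active" (no number reported), so neither can be placed on a scale against compound 1.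

The next compound to be tested is compound 4 `COC(=O)C[C@H]1C[C@H](O)[C@H](C)[C@@H](c2ccccc2)N1`. Its relation to compound 1 is purely one of configuration: the two compounds have the same atoms and bonds and differ only in configuration as drawn: 3 of 4 stereo elements differ; a stereocentre at a saturated ring carbon is drawn S in compound 1 and R in compound 4; a stereocentre at a saturated ring carbon is drawn R in compound 1 and S in compound 4; a stereocentre at a saturated ring carbon is drawn R in compound 1 and S in compound 4. Within the data shown here, no atoms leave or enter, and the data contain no measured step between compounds that differ in one place, so nothing shows directly how large a change of this kind should be.

Any expectation is therefore a loose one. It starts from compound 1 at 5400 nM, and compound 2 at "not active" (no number reported) suggests that a number is not assured in this series. A moderate loss of potency is expected, and a result of not active would be no surprise. The expected change is a 1.9-fold higher number from compound 1 to compound 4 (0.27 log units; within the scatter). For compound 4 the estimated value is 10000 nM, with an expected range of 3000 nM to 35000 nM.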

Compound 4, half-maximal inhibitory concentration: "not active" (no number reported)
Compound 4: no number reported; no gap can be computed for the estimate.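

Compound 4 is recorded in this assay as not active, without a number, so no new step can be read between it and compound 1, which gives 5400 nM. The compounds shown leave open which of the differing stereocentres bears on this result, and the pair offers only one firm point: the fact that compounds 1 and 4 differ only in the configuration as drawn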